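Returning to an indole from 4-vinylphenyl

The source may report more compounds than this note shows. Statements on the series, on what has been measured and on what is new or still open speak of the compounds shown alone.

Within the data shown here, in a functional assay on B16-F0 cells (Mus musculus) for inhibition, read by CCK-8 assay, with a stated time of 48 h (on this read-out higher numbers stand for weaker inhibition and lower numbers for stronger inhibition), compound 1 `COc1cc(-c2ccnc3cc(-c4ccc5cc[nH]c5c4)nn23)cc(OC)c1OC` gives 55 nM, while compound 2 `C=Cc1ccc(-c2cc3nccc(-c4cc(OC)c(OC)c(OC)c4)n3n2)cc1` gives 788 nM, the higher of the two numbers so far. Compound 3 `COc1cc(-c2ccnc3cc(-c4ccc5ccn(C)c5c4)nn23)cc(OC)c1OC` differs from compound 2 as follows: 1-methyl-1H-indol-6-yl in place of 4-vinylphenyl on an aromatic carbon. Among the measured compounds shown here, the one measured step that bears on this is a 14-fold higher number from compound 1 to compound 2 (1.16 log units; beyond the scatter), with 4-vinylphenyl in place of 1H-indol-6-yl. For the measured compounds named here, the present change runs the other way, and the methyl it carries has no measured step of its own, so a large move to a lower number is expected in this assay, namely a 7.2-fold lower number from compound 2 to compound 3 (0.86 log units; beyond the scatter). Compound 3 is estimated at 110 nM, within a range of 35 nM to 350 nM.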

Compound 3, half-maximal inhibitory concentration: 657 nM
Compound 3: middle estimate off by 6.0-fold (0.78 log units), on the low side, outside the stated range (above it).
By their numbers in this assay, from the lowest: compound 1; then compounds 3 and 2 (each within the scatter of the next).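

Methyl in place of hydrogen on the aromatic nitrogen of the indole is a large step in this assay (a 12-fold higher number from compound 1 to compound 3 (1.08 log units; beyond the scatter)), so the indole ring alone does not bring back the number of compound 1. At this position, 1-methyl-1H-indol-6-yl and 4-vinylphenyl cannot be told apart (a 1.2-fold lower number from compound 2 to compound 3 (0.08 log units; within the scatter)). No measurement at hand explains the methyl step.

Open, going by these compounds, is whether an ethyl group, or a longer chain ending in an amine, on that nitrogen would match methyl. Also open, on these data alone, is whether the methyl step holds for an indole attached through another ring carbon.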